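Oxime versus semicarbazone on a growth-inhibition series

The source may report more compounds than this note shows. Statements on the series, on what has been measured and on what is new or still open speak of the compounds shown alone.

Measured so far:
- compound 1 `COc1cc2c(cc1CC=C(C)C)/C(=N/NC(N)=O)C[C@@H](c1ccc(O)cc1)O2`: 77%
- compound 2 `CCOc1ccc([C@@H]2CC(=O)c3cc(CC=C(C)C)c(OC)cc3O2)cc1`: 37%

In a functional assay on A549 cells (Homo sapiens) for inhibition, read by sulforhodamine B assay, with a stated time of 48 h, tested at 50 uM (on this read-out lower numbers stand for less inhibition of growth and higher numbers for more inhibition of growth at the one concentration tested), compound 1 gives 77% and stands highest of the two numbers at hand. Compound 2 gives 37% in this assay, a gap to compound 1 that lies beyond the scatter. For the measured compounds named here, no pair of measured compounds differs in only one place, so no single change has yet been tied to a shift in this assay.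

Compound 3 `COc1cc2c(cc1CC=C(C)C)/C(=N/O)C[C@@H](c1ccc(O)cc1)O2` is not yet measured. It differs from compound 1 in one place: hydroxy in place of ureido on a double-bonded nitrogen. The double-bonded nitrogen and the rest of the core of compound 1 are kept.

Going by the values given here, with no measured step of this kind to lean on, a small drop at most is expected, possibly none beyond the scatter, since compound 1 already gives 77% with the larger group in that place. For compound 3 the estimate is 65%, within 42% to 85%, meaning an expected step of a number 12 percentage points lower from compound 1 to compound 3 (beyond the scatter).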

Compound 3, percent growth inhibition at one concentration: 80%
Estimate against measurement, compound 3: 15 percentage points below; low and high end bracket the measured number.
By their numbers in this assay, from the lowest: compound 2; then compounds 1 and 3 (each within the scatter of the next).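

In this assay, hydroxy in place of ureido on a double-bonded nitrogen gives a number 3 percentage points higher from compound 1 to compound 3 (within the scatter), so this first single-place change leaves the number unchanged within the scatter. At this place, therefore, the four heavy atoms of ureido are not needed to keep growth inhibition at this level, as the single oxygen of hydroxy serves equally well on the core of compound 1. No measurement at hand gives a reason for this result.

Still open, as far as these compounds go, is how far this tolerance extends: whether a methoxy group, an amine or a longer chain such as benzyloxy on the double-bonded nitrogen would hold the number. Also open, from the compounds shown here alone, is what a carbonyl in place of the double-bonded nitrogen does alone, since compound 2 differs from compound 1 and compound 3 in more than one place.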